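Series notes: oxazole exchange from compound 3 to compound 4

The source may report more compounds than this note shows. Statements on the series, on what has been measured and on what is new or still open speak of the compounds shown alone.

Three compounds carry numbers in a physicochemical assay for lipophilicity; a lower number here means a more polar compound, a higher number a more lipophilic compound. Compound 1 `Cc1ccc(NC(=O)CC(CCC(=O)O)c2nnc(CCCC(C)C)n2C2CC2)c(C)c1` gives 2.9. Going by the values given here, compound 2 `Cc1ccc(NC(=O)CC(CCC(N)=O)c2nnc(CCCC(C)C)n2C2CC2)c(C)c1` gives 3.4, and the single counted step, a number 0.50 log units higher from compound 1 to compound 2 (beyond the scatter), is the only measured step in the set. Compound 3 `Cc1ccc(NC(=O)C[C@H](CCC(=O)O)c2noc(-c3cc(CC(C)C)no3)c2C2CC2)c(Cl)c1` gives 3.8 and stands highest of the three, with compound 2 nearest and compound 1 furthest, both gaps beyond the scatter.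

Compound 4 `Cc1ccc(NC(=O)C[C@H](CCC(=O)O)c2noc(-c3cc(CC(C)(C)C)on3)c2C2CC2)c(Cl)c1` differs from compound 3 in one place: 5-neopentyl-1,2-oxazol-3-yl in place of 3-isobutyl-1,2-oxazol-5-yl on an aromatic carbon. Among the compounds with values here, no measured step covers an exchange of this kind; the one step on record concerns the substituent on the carbonyl carbon and does not bear on it. What remains is the comparison of the two groups as counted, the entering group being somewhat larger than the leaving one with donors and acceptors unchanged. A small upward movement in this assay is therefore expected for compound 4, a number 0.30 log units higher from compound 3 to compound 4 (within the scatter), which may still fall within the scatter. Compound 4 is estimated at 4.1, in the range 3.7 to 4.5.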

Compound 4, distribution coefficient: 4.2
Compound 4: middle estimate off by 0.10 log units, on the low side, within the range that was stated.
By their numbers in this assay, from the lowest: compound 1; then compound 2; then compound 3; then compound 4.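

In this assay, going by these compounds alone, 5-neopentyl-1,2-oxazol-3-yl in place of 3-isobutyl-1,2-oxazol-5-yl gives a number 0.40 log units higher from compound 3 to compound 4 (beyond the scatter), the first step on record at this aromatic carbon, next to the ring oxygen. The entering and leaving groups have the same counted hydrogen-bond donors and acceptors but differ in both the chain and the ring attachment, and this single step does not separate those two changes. Nothing on hand accounts for the size or direction of this step.

On these data alone, it remains open how far the step belongs to the neopentyl chain and how far to the ring attachment, and whether an amine or a longer alkyl chain on the same ring would move the number further. Also open, as far as these compounds go, is whether amino in place of hydroxy on the carbonyl carbon, seen in a number 0.50 log units higher from compound 1 to compound 2 (beyond the scatter), would give a similar step on the core of compound 4.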